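Changing one amide side group of compound 3

A few compounds are considered here, and "the series" means these few. Any claim that something is new, unique, unknown or untested is made for them only; others in the source may bear on it.

Compound 1 `CCn1c(C(=O)N(CCC#N)CCC#N)ccc1C(CC)(CC)c1ccc(OCCC(O)(CC)CC)c(C)c1`: > 50000 nM, a limit
Compound 2 `CCn1c(C(=O)Nc2ccc(OC(F)(F)F)cc2)ccc1C(CC)(CC)c1ccc(OCCC(O)(CC)CC)c(C)c1`: > 50000 nM, a limit
Compound 3 `CCn1c(C(=O)NC(CC(=O)O)C(=O)OC)ccc1C(CC)(CC)c1ccc(OCCC(O)(CC)CC)c(C)c1`: 25200 nM

Going by the values given here, in a functional assay on Caco-2 cells (Homo sapiens) for antiproliferative activity, read by MTT assay, with a stated time of 48 h (on this read-out higher numbers stand for weaker inhibition and lower numbers for stronger inhibition), compound 3 gives 25200 nM, the only actual number in this set. The other two readings are limits: the limit of > 50000 nM in this assay, at which 2 of the 3 values shown sit.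

Compound 4 `CCn1c(C(=O)NC(CO)CCO)ccc1C(CC)(CC)c1ccc(OCCC(O)(CC)CC)c(C)c1` differs from compound 3 by a group of 6 heavy atoms (4 carbon, 2 oxygen; no ring) in place of a group of 9 heavy atoms (5 carbon, 4 oxygen; no ring), on an amide-type nitrogen. The entering group is 3-hydroxy-1-(hydroxymethyl)propyl.

Two measured steps end at compound 3: an at least 1.9-fold lower number from compound 1 to compound 3 (0.29 log units; that floor lies within the scatter) and an at least 1.9-fold lower number from compound 2 to compound 3 (0.29 log units; that floor lies within the scatter). Both are only floors, so neither gives a firm size, and no clear change is expected in this assay. The expected move is a 1.2-fold higher number from compound 3 to compound 4 (0.08 log units; within the scatter). For compound 4 the estimated value is 30000 nM, with an expected range of 14000 nM to 60000 nM.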

Compound 4, half-maximal inhibitory concentration: 40200 nM
The estimate for compound 4 lay 1.3-fold (0.13 log units) below the measured number; the range from low to high includes it.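

In this assay, the exchange on this amide-type nitrogen now has a size that can be read: a 1.6-fold higher number from compound 3 to compound 4 (0.20 log units; within the scatter). Replacing the group of compound 3 with 3-hydroxy-1-(hydroxymethyl)propyl therefore produces no clear change. The steps from the other two compounds, an at least 1.2-fold lower number from compound 2 to compound 4 (0.09 log units; that floor lies within the scatter) and an at least 1.2-fold lower number from compound 1 to compound 4 (0.09 log units; that floor lies within the scatter), are only floors, set by a limit: the limit of > 50000 nM in this assay, at which 2 of the 4 values shown sit.

From the compounds shown here alone, it remains open whether an amine or a longer chain on this amide-type nitrogen would move the number beyond the scatter.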